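Chloro to methyl on the 4-chlorophenyl group

This account rests on a few compounds, and the source may have more. Where it says the series, first, only, none or still open, it means among the compounds named here.

In a functional assay on MCF7 cells (Homo sapiens) for inhibition, read by MTT assay, with a stated time of 72 h (on this read-out higher numbers stand for weaker inhibition and lower numbers for stronger inhibition), compound 3 (`Cc1cc2occ(-c3nc(-c4ccccc4)c(-c4ccccc4)n3-c3ccc(Cl)cc3)c(=O)c2cc1Cl`) gives 12500 nM. Compound 2 (`Cc1cccc(-n2c(-c3coc4cc(C)c(Cl)cc4c3=O)nc(-c3ccccc3)c2-c2ccccc2)c1`) gives 12500 nM, and these two share the highest number of the three. Compound 1 (`Cc1cc2occ(-c3nc(-c4ccccc4)c(-c4ccccc4)n3-c3ccc(Cl)c(Cl)c3)c(=O)c2cc1Cl`) gives 1560 nM.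

Compound 4 (`Cc1ccc(-n2c(-c3coc4cc(C)c(Cl)cc4c3=O)nc(-c3ccccc3)c2-c2ccccc2)cc1`) differs from compound 3 as follows: methyl in place of chloro on an aromatic carbon. This is methyl in place of chloro on an aromatic carbon, or 4-chlorophenyl to 4-methylphenyl.

Among the compounds with values here, no measured step makes this exact swap. The closest is no change at the digits printed from compound 2 to compound 3 (within the scatter), where 4-chlorophenyl replaces 3-methylphenyl on the aromatic nitrogen. The two larger steps, an 8.0-fold higher number from compound 1 to compound 2 (0.90 log units; beyond the scatter) and an 8.0-fold higher number from compound 1 to compound 3 (0.90 log units; beyond the scatter), both start from the 3,4-dichlorophenyl group, which compound 4 lacks, so they bear on this change less directly.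

No change beyond the scatter is therefore expected in this assay, and the expected step is a 1.0-fold lower number from compound 3 to compound 4 (0.02 log units; within the scatter). Compound 4 is estimated at 12000 nM, with an expected range of 5000 nM to 28000 nM.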

Compound 4, half-maximal inhibitory concentration: 12500 nM
Estimate against measurement, compound 4: 1.0-fold (0.02 log units) below, within the range that was stated.
By their numbers in this assay, from the lowest: compound 1; then compounds 2, 3 and 4 (each within the scatter of the next).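

In this assay, the direct swap of chloro for methyl on the aromatic carbon para to a large group gives no change at the digits printed from compound 3 to compound 4 (within the scatter), so at this position the two groups cannot be told apart on this read-out. The methyl group's placement shows no separation either, with no change at the digits printed from compound 2 to compound 4 (within the scatter) for 4-methylphenyl in place of 3-methylphenyl. Only the 3,4-dichlorophenyl group remains apart, with an 8.0-fold higher number from compound 1 to compound 4 (0.90 log units; beyond the scatter), and compounds 2, 3 and 4 read level.

No measurement available here gives a reason for these results. Open questions are whether an amine, a carboxylic acid or a longer chain on this aromatic carbon would move the number, and whether the step from compound 1 depends on having both chloro groups.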